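Linker extension in the series: expectation for compound 3

This account rests on a few compounds, and the source may have more. Where it says the series, first, only, none or still open, it means among the compounds named here.

Working notes. In an assay on HEK293 cells for positive allosteric modulation of metabotropic glutamate receptor 3 (Rattus norvegicus), read by thallium flux, with a stated time of 2.5 min (a lower number here means a smaller maximal response, a higher number a larger maximal response), compound 1 `COc1cc(C(=O)O)ccc1OCCCCOc1ccc(C(=O)C(C)C)c(O)c1C` gives 25.6%. Compound 2 `Cc1c(OCCCCOc2ccc(C(=O)O)cc2)ccc(C(=O)CC2CCCC2)c1O` gives 26.7% in this assay; the two values lie within the usual scatter of each other, so neither stands apart. Compound 3 `Cc1c(OCCCCOCOc2ccc(C(=O)O)cc2)ccc(C(=O)CC2CCCC2)c1O` is not yet measured; it differs from compound 2 by (4-carboxyphenoxy)methyl in place of 4-carboxyphenyl on an oxygen on a saturated carbon. Among the compounds with values here, no step between measured compounds covers such a change, so the expected step of a number 0.7 percentage points lower from compound 2 to compound 3 (within the scatter) is small, not beyond the scatter in either direction. Compound 3 is estimated at 26%, with a range from 13% to 40%.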

Compound 3, largest response reached (reported as percent of maximum), in percent of the reference or control that the assay uses: 46.9%
The estimate for compound 3 lay 20.9 percentage points below the measured number; the measured number lies above the stated range.
By their numbers in this assay, from the lowest: compounds 1 and 2 (each within the scatter of the next); then compound 3.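

In this assay, (4-carboxyphenoxy)methyl in place of 4-carboxyphenyl on an oxygen on a saturated carbon gives a number 20.2 percentage points higher from compound 2 to compound 3 (beyond the scatter). Within the data shown here, this is the first single-place step, and it shows that the maximal response is sensitive to this change at this position, with the carboxylic acid and the aromatic ring both retained. Nothing available bears on the cause of this rise.

Still open, on these data alone, is whether an all-carbon chain or an amine in place of the entering oxygen gives a comparable response. As far as these compounds go, whether a still longer chain raises the response further is also open.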